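The compounds below may be only part of what the source reports. "The series", "measured", "known", "first", "only" and "open" are said of these compounds alone.

Compound 1 `COc1nc(C(C)(C)C)ccc1[C@@H](c1ccccc1)[C@@](O)(CCN(C)C)c1cccc2ccccc12` gives 27.6 ug/mL in a toxicity assay on Vero cells (Chlorocebus sabaeus) for cytotoxicity (on this read-out lower numbers stand for higher toxicity in this test and higher numbers for lower toxicity in this test), the lowest of the two plain numbers shown. Compound 2 `COc1nc(C2CCCCC2)ccc1[C@@H](c1ccccc1)[C@@](O)(CCN(C)C)c1cccc2ccccc12` gives 32.3 ug/mL in this assay, and the step of a 1.2-fold higher number from compound 1 to compound 2 (0.07 log units; within the scatter) stays within the scatter. Compound 3 `COc1nc(-c2ccncc2)ccc1[C@@H](c1ccccc1)[C@@](O)(CCN(C)C)c1cccc2ccccc12` reaches only a limit in this assay, > 50 ug/mL. That limit is the limit of > 50 ug/mL in this assay, at which 1 of the 3 values shown sits, so the step of an at least 1.8-fold higher number from compound 1 to compound 3 (0.25 log units; that floor lies within the scatter) and the step of an at least 1.5-fold higher number from compound 2 to compound 3 (0.18 log units; that floor lies within the scatter) have floors only. Compound 4 `COc1nc(-c2ccc(Cl)c(F)c2)ccc1[C@@H](c1ccccc1)[C@@](O)(CCN(C)C)c1cccc2ccccc12` differs from compound 1 in one place: 4-chloro-3-fluorophenyl in place of tert-butyl on an aromatic carbon. Both measured steps away from compound 1 are small, one within the scatter and one a floor that lies within the scatter, so no step beyond the scatter is expected in this assay. Compound 4 is estimated at 25 ug/mL, ranging from 10 ug/mL to 50 ug/mL, an expected step of a 1.1-fold lower number from compound 1 to compound 4 (0.04 log units; within the scatter).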

Compound 4, half-maximal cytotoxic concentration: > 50 ug/mL
Compound 4: no number, only a limit (the forecaster's own chance of this, stated with the estimate: 15%); middle value at least 2.0-fold (0.30 log units) away from the limit.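

Compound 4 gives only a limit in this assay, as compound 3 does: the limit of > 50 ug/mL in this assay, at which 2 of the 4 values shown sit. The steps are an at least 1.8-fold higher number from compound 1 to compound 4 (0.25 log units; that floor lies within the scatter) and an at least 1.5-fold higher number from compound 2 to compound 4 (0.18 log units; that floor lies within the scatter), so neither goes beyond the scatter. A carbon-only aromatic ring carrying chlorine and fluorine reaches the same limit as pyridin-4-yl, so a ring nitrogen in this group is not needed to reach it, while the step between those two compounds cannot be read.

From the compounds shown here alone, how far either compound lies past the limit stays open. So does what an amine or a carboxylic acid would give at this position.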